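Swapping a Benzyl Group for an Aryl Group on the Pyrimidine

The source may report more compounds than this note shows. Statements on the series, on what has been measured and on what is new or still open speak of the compounds shown alone.

Compound 1 `Cc1ccccc1Nc1nc(Nc2cc(Cl)ccn2)ncc1Cl`: 39600 nM
Compound 2 `Cc1ccc(CNc2nc(Nc3ccc(N4CCN(C)CC4)cn3)ncc2Cl)cc1`: 12700 nM

Among the compounds with values here, in a functional assay on Jurkat cells (Homo sapiens) for inhibition, read by CCK-8 assay, with a stated time of 48 h (a lower number here means a stronger inhibitor of growth, a higher number a weaker inhibitor of growth), compound 2 gives the lower of the two numbers so far, and the gap to compound 1 lies beyond the usual scatter. Compound 3 `CC(C)c1cccc(Nc2nc(Nc3ccc(N4CCN(C)CC4)cn3)ncc2Cl)c1` differs from compound 2 in one place: 3-isopropylphenyl in place of 4-methylbenzyl on a nitrogen on an aromatic ring. Within the data shown here, no measured pair shows this change, so the outcome is uncertain. Because compound 2 sits at 12700 nM, a modest gain or no change beyond the scatter is expected, giving an estimated step of a 1.4-fold lower number from compound 2 to compound 3 (0.15 log units; within the scatter). Compound 3 is therefore expected to reach about 9000 nM, within 3000 nM to 30000 nM.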

Compound 3, concentration for 50% growth inhibition: 12300 nM
Beside the measured number, compound 3's estimate is 1.4-fold (0.14 log units) below it, and the stated range covers the measured number.
By their numbers in this assay, from the lowest: compounds 3 and 2 (each within the scatter of the next); then compound 1.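

In this assay, putting 3-isopropylphenyl in place of 4-methylbenzyl on a nitrogen on an aromatic ring gives a 1.0-fold lower number from compound 2 to compound 3 (0.01 log units; within the scatter) and so leaves the reading within the scatter. This single-place comparison shows that this position tolerates the exchange of one of these carbon-only groups for the other without a measurable difference. No measured evidence bears on why the two compounds read alike. On these data alone, what remains open is whether an amine or a carboxylic acid on the ring of this group, or a simple alkyl chain in place of the ring, would move the number beyond the scatter.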